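The compounds below may be only part of what the source reports. "The series", "measured", "known", "first", "only" and "open" are said of these compounds alone.

Of the compounds shown here, three sharing one core have been measured in an assay on HEK293 cells for binding affinity to Neuropeptide Y receptor type 5 (Homo sapiens), read by radioligand binding; on this read-out higher numbers stand for weaker inhibition and lower numbers for stronger inhibition. Compound 1 `Cc1cc(C(=O)Nc2ccc(F)cc2)nn1-c1cccc(C(F)(F)F)c1` gives 800 nM. Compound 2 `Cc1cc(C(=O)Nc2cc(Cl)cc(Cl)c2)nn1-c1cccc(C(F)(F)F)c1`, which carries 3,5-dichlorophenyl on the amide-type nitrogen, gives 150 nM. Compound 3 `Cc1cccc(-n2nc(C(=O)Nc3cc(Cl)cc(Cl)c3)cc2C)c1` gives 218 nM. Among these three numbers compound 2 has the lowest, yet its gap to compound 3 lies within the scatter, so those two cannot be ranked; only the gap to compound 1 is clearly larger.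

Compound 4 `Cc1ccccc1NC(=O)c1cc(C)n(-c2cccc(C(F)(F)F)c2)n1` has not yet been measured. It differs from compound 2 in one place: 2-methylphenyl in place of 3,5-dichlorophenyl on an amide-type nitrogen. Among the measured compounds shown here, one measured step bears directly on this place: a 5.3-fold lower number from compound 1 to compound 2 (0.73 log units; beyond the scatter), a modest but real change produced by swapping the group on the amide-type nitrogen. The other step, a 1.5-fold higher number from compound 2 to compound 3 (0.16 log units; within the scatter), concerns a different position and stayed within the scatter. For the measured compounds named here, since compound 4 removes the 3,5-dichlorophenyl that accompanied the low number of compound 2, a higher number is expected for compound 4 because of a 5.3-fold lower number from compound 1 to compound 2 (0.73 log units; beyond the scatter), although the entering group has no precedent here. The step expected here is a 3.3-fold higher number from compound 2 to compound 4 (0.52 log units; beyond the scatter). Compound 4 is therefore estimated at 500 nM, with a range from 180 nM to 1500 nM.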

Compound 4, half-maximal inhibitory concentration: 573 nM
Compound 4: middle estimate off by 1.1-fold (0.06 log units), on the low side; measured number inside the range.
By their numbers in this assay, from the lowest: compounds 2 and 3 (each within the scatter of the next); then compounds 4 and 1 (each within the scatter of the next).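

In this assay, the step of a 3.8-fold higher number from compound 2 to compound 4 (0.58 log units; beyond the scatter) shows that the low number of compound 2 is lost with a second replacement for 3,5-dichlorophenyl, not only with the 4-fluorophenyl of compound 1. The step of a 1.4-fold lower number from compound 1 to compound 4 (0.14 log units; within the scatter) lies within the scatter, so 2-methylphenyl and 4-fluorophenyl cannot be ranked here, even though one carries a methyl and the other a fluorine; since all three groups hold one six-membered aromatic ring of carbon only, that ring by itself does not bring the number down to that of compound 2. Nothing measured here explains why 3,5-dichlorophenyl stands apart from the other two groups on the amide-type nitrogen.

As far as these compounds go, it stays open whether a phenyl ring with a single chlorine, a pyridine ring or a cyclohexyl group on this nitrogen would give a number close to that of compound 2. Also open, from the compounds shown here alone, is whether the change to 2-methylphenyl would have a step of similar size on the core of compound 3, which carries methyl in place of trifluoromethyl on an aromatic carbon.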